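An acetyl swap on the shared core

The compounds below may be only part of what the source reports. "The series", "measured", "known", "first", "only" and "open" are said of these compounds alone.

Compound 1 `O=C(c1cnco1)N1CCC(C(=O)N2N=CC[C@H]2c2ccccc2)CC1`: 2.1 L/kg
Compound 2 `Cc1nnc(N2CCC(C(=O)N3N=CC[C@H]3c3ccccc3)CC2)o1`: 1.6 L/kg
Compound 3 `O=C(c1cn[nH]c1)N1CCC(C(=O)N2N=CCC2c2ccccc2)CC1`: 1.6 L/kg

These three compounds were measured in an ADME assay on the whole organism (Rattus norvegicus) for pharmacokinetics, at a dose of 1 mg/kg by the intravenous route; on this read-out lower numbers stand for narrower distribution and higher numbers for wider distribution into tissues. Compound 2 stands level with compound 3 at the digits shown, and all three values lie within the scatter of one another. Compound 4 `CC(=O)N1CCC(C(=O)N2N=CC[C@H]2c2ccccc2)CC1` differs from compound 2 at one place: acetyl in place of 5-methyl-1,3,4-oxadiazol-2-yl on an amine nitrogen in a ring. Among the measured compounds shown here, one measured step bears on this change, as it alters the group on the same nitrogen: a 1.3-fold lower number from compound 1 to compound 2 (0.12 log units; within the scatter). That step stayed within the scatter, so no step beyond the scatter is expected in this assay. The estimated step is a 1.1-fold higher number from compound 2 to compound 4 (0.03 log units; within the scatter). For compound 4 the expected value is 1.7 L/kg, with an estimated range from 1 L/kg to 2.9 L/kg.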

Compound 4, volume of distribution at steady state: 1.7 L/kg
The estimate for compound 4 equals the measured number at the digits printed; the measured number falls inside the stated range.
By their numbers in this assay, from the lowest: compounds 2, 3, 4 and 1 (each within the scatter of the next).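

In this assay, among the compounds shown here, acetyl, which has no ring, proved interchangeable with the five-membered aromatic groups carried by the earlier compounds on the amine nitrogen in a ring. The step of a 1.1-fold higher number from compound 2 to compound 4 (0.03 log units; within the scatter) and the step of a 1.2-fold lower number from compound 1 to compound 4 (0.09 log units; within the scatter) both stay within the scatter, so at this position the distribution read-out does not depend on an aromatic ring being present. No measurement here offers an explanation for this insensitivity.

The compounds shown leave open whether the read-out would stay level with an amine or a carboxylic acid at this position, since all four groups here carry no net charge.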